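The source may hold more compounds than are shown below. What is called first, only, known or untested is meant among the compounds shown, and "the series" means these compounds.

The measured compounds:
compound 1, `Brc1cn2ccnc2c(-c2ccc3ncn(C4CCCCC4)c3c2)n1`, in a functional assay on RPMI-8226 cells (Homo sapiens) for inhibition, read by sulforhodamine B assay, with a stated time of 48 h, tested at 10 uM (on this read-out lower numbers stand for less inhibition and higher numbers for more inhibition at the one concentration tested (going by the name of the read-out)), compound 1 gives 14.9%.
compound 2, `c1ccc(-c2cn3ccnc3c(-c3ccc4ncn(C5CCCCC5)c4c3)n2)cc1`, in this assay compound 2 gives 85.7%.
compound 3, `c1cn2cc(-c3ccsc3)nc(-c3ccc4ncn(C5CCCCC5)c4c3)c2n1`, in this assay compound 3 gives 37.9%.

Among these three, compound 3 stands in the middle: it sits beyond the scatter above compound 1, as the step of a number 23 percentage points higher from compound 1 to compound 3 (beyond the scatter) shows, and beyond the scatter below compound 2, as the step of a number 47.8 percentage points lower from compound 2 to compound 3 (beyond the scatter) shows. Compound 4, `CC(=O)c1ccc(-c2cn3ccnc3c(-c3ccc4ncn(C5CCCCC5)c4c3)n2)cc1`, has not yet been measured in this assay. Its change from compound 3 is 4-acetylphenyl in place of thiophen-3-yl on an aromatic carbon.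

For the measured compounds named here, the steps that bear on this change are the two involving the phenyl group. The step of a number 70.8 percentage points higher from compound 1 to compound 2 (beyond the scatter) was large, and the step of a number 47.8 percentage points lower from compound 2 to compound 3 (beyond the scatter) was large in the other direction, so a six-membered carbon ring at this position has so far given much more inhibition than the thiophen-3-yl group. Going by the values given here, compound 4 carries an acetyl on that ring, for which no measured step exists, so the size is less certain, but the direction is expected to be upward. The account therefore expects a step of a number 34.1 percentage points higher from compound 3 to compound 4 (beyond the scatter) from compound 3 to compound 4, placing compound 4 at an estimated 72%, with a range from 45% to 95%.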

Compound 4, a percentage reported as inhibition, at one concentration (the size of the read-out at that concentration, not a potency): 20.8%
For compound 4 the middle estimate is 51.2 percentage points above the measured one; measured number outside the range, below it.
By their numbers in this assay, from the lowest: compounds 1 and 4 (each within the scatter of the next); then compound 3; then compound 2.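

In this assay the phenyl ring alone does not settle the outcome at this position: adding an acetyl to it gives a number 64.9 percentage points lower from compound 2 to compound 4 (beyond the scatter), so what the ring carries counts as much as the ring itself. The 4-acetylphenyl group also ranks under the thiophen-3-yl group, with a number 17.1 percentage points lower from compound 3 to compound 4 (beyond the scatter), which reverses the order that phenyl had set, while the replacement of bromo gives a number 5.9 percentage points higher from compound 1 to compound 4 (within the scatter), so the added ring brings no clear gain once it bears the acetyl. Nothing available explains this loss of inhibition.

On these data alone, it remains open whether a methyl, an amine or a carboxylic acid on the phenyl ring would lower the inhibition as the acetyl does or keep it near that of compound 2. As far as these compounds go, it is equally open whether the acetyl's place on that ring matters.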